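Removing a Methoxy Group: From Compound 1 to Compound 3

The source may report more compounds than this note shows. Statements on the series, on what has been measured and on what is new or still open speak of the compounds shown alone.

Compound 1 `COc1cccc(CNC(=O)c2nc(Br)c3cccnc3c2N[C@H]2CC[C@H](N)CC2)c1`: 6000 nM
Compound 2 `O=C(NCc1ccc(F)cc1)c1nc(Br)c2cccnc2c1N1CCNCC1`: 6000 nM

Of the compounds shown here, two have so far been tested in a functional assay on SK-BR-3 cells (Homo sapiens) for cytotoxicity, read by MTT assay, with a stated time of 72 h; a higher number here means a weaker inhibitor, a lower number a stronger inhibitor. In this assay compound 1 gives 6000 nM, and in this assay compound 2 gives 6000 nM. The two values stand level at the digits shown, so nothing separates compound 1 from compound 2 here; no step between them is drawn, because the two differ in more than one place, and only their two values can be compared.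

The next compound to be tested is compound 3 `N[C@H]1CC[C@H](Nc2c(C(=O)NCc3ccccc3)nc(Br)c3cccnc23)CC1`. It differs from compound 1 in one place: hydrogen in place of methoxy on an aromatic carbon. The aromatic ring that carries the change sits at the benzylamino end of the amide, far from the remaining parts of the shared core.

For the measured compounds named here, with only two measured compounds, both at the same level, there is no measured step to guide the size of the change. A small group leaving a distant benzyl ring is expected to move this assay little, in no clear direction, and the step from compound 1 to compound 3 is estimated to stay within the scatter, no change at the digits printed from compound 1 to compound 3 (within the scatter). Compound 3 is therefore expected to give about 6000 nM in this assay, within a range of 2500 nM to 15000 nM.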

Compound 3, half-maximal inhibitory concentration: 8000 nM
Estimate against measurement, compound 3: 1.3-fold (0.12 log units) below; the range from low to high includes it.
By their numbers in this assay, from the lowest: compounds 1, 2 and 3 (each within the scatter of the next).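

In this assay, for the compounds shown here, the first comparison that differs in one place reads a 1.3-fold higher number from compound 1 to compound 3 (0.12 log units; within the scatter), so hydrogen in place of methoxy on an aromatic carbon, meta to a large group, is a difference this read-out does not resolve. Compound 1 and compound 2 could only be set side by side across more than one difference, whereas the 3-methoxybenzyl and benzyl groups can now be compared directly, and the methoxy group proves not to be required for the level of cytotoxicity seen with compound 1. Nothing available explains this result, and the reason for it remains unknown.

Only one replacement at this carbon is shown, so it remains open whether an amine, a carboxylic acid or a longer chain such as butoxy there would also leave the reading within the scatter of compound 1. As far as these compounds go, it is also open whether the same replacement would read alike on a compound carrying the other substituents of compound 2.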